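This account rests on a few compounds, and the source may have more. Where it says the series, first, only, none or still open, it means among the compounds named here.

Compound 1 `COc1ccc2c(c1)[n+]([O-])nc(NCOC(C)c1ccccc1)[n+]2[O-]` gives 220 nM in a functional assay on KB cells (Homo sapiens) for cytotoxicity, read by MTT assay, with a stated time of 72 h; a lower number here means a stronger inhibitor, a higher number a weaker inhibitor.
Compound 2 `COCNc1n[n+]([O-])c2ccccc2[n+]1[O-]` gives 1580 nM in this assay.

Of the two numbers, compound 2 stands at the higher one, the weaker end; compound 1 sits lower, and that gap lies beyond the usual scatter. Compound 3 `CCCCCCCOCNc1n[n+]([O-])c2ccccc2[n+]1[O-]` carries hexyl in place of hydrogen on a saturated chain carbon bound to an oxygen on a saturated carbon. Among the measured compounds shown here, no measured step of this kind exists here, so the expectation rests on compound 1 alone, whose longer side chain goes with 220 nM. From that, a moderate move toward a lower number is expected, shown as a 3.2-fold lower number from compound 2 to compound 3 (0.50 log units; beyond the scatter). Compound 3 is estimated at 500 nM, within 150 nM to 1600 nM.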

Compound 3, half-maximal inhibitory concentration: 2520 nM
The estimate for compound 3 lay 5.0-fold (0.70 log units) below the measured number; measured number above the stated range.
By their numbers in this assay, from the lowest: compound 1; then compounds 2 and 3 (each within the scatter of the next).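

In this assay, hexyl in place of hydrogen on a saturated chain carbon bound to an oxygen on a saturated carbon gives a 1.6-fold higher number from compound 2 to compound 3 (0.20 log units; within the scatter). At this position, then, a methyl end can become a heptyl end and the two numbers still cannot be told apart. Nothing measured here offers a reason for this result. From the compounds shown here alone, whether an amine or a carboxylic acid at the end of this chain would shift the number stays open. So does whether a longer chain would.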